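Shortening the branched alkyl group on two related cores

A few compounds are considered here, and "the series" means these few. Any claim that something is new, unique, unknown or untested is made for them only; others in the source may bear on it.

Compound 1 `COc1ccc(NC(=O)C(=O)c2cn(C(C)C)c3ccccc23)cn1` and compound 3 `CCC(C)n1cc(C(=O)C(=O)Nc2ccc(OC)nc2)c2ccccc21` are built on one core, while compound 2 `COc1ccc(NC(=O)C(=O)c2cc(C(C)C)n3ccccc23)cn1` and the unmeasured compound 4 `CCc1cc(C(=O)C(=O)Nc2ccc(OC)nc2)c2ccccn12` are built on another. The difference between the two cores is not broken down here. In a functional assay on FaDu cells (Homo sapiens) for cytotoxicity, read by MTT assay, with a stated time of 72 h (a higher number here means that more compound is tolerated, a lower number that less compound is tolerated), compound 3 gives 68 nM, and compound 1 gives 85 nM. The change between these two is hydrogen in place of methyl on a saturated chain carbon, two bonds along the chain from an aromatic nitrogen, and in this assay it amounts to a 1.3-fold higher number from compound 3 to compound 1 (0.10 log units; within the scatter). In this assay compound 2 gives 160 nM; this is the highest of the three numbers, but the gap to compound 1 is within the scatter and only the gap to compound 3 lies beyond it.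

Compound 4 is reached from compound 2 by hydrogen in place of methyl on a saturated chain carbon bound to an aromatic carbon and a saturated chain carbon. Within the data shown here, this is the same kind of change as the one from compound 3 to compound 1, but not the same change: there the saturated chain carbon sits two bonds along the chain from an aromatic nitrogen, here it is bound to an aromatic carbon and a saturated chain carbon. Among the measured compounds shown here, the only measured step of this kind is a 1.3-fold higher number from compound 3 to compound 1 (0.10 log units; within the scatter), and a step of similar small size is expected on the second core as well. In this assay the expected step is a 1.3-fold higher number from compound 2 to compound 4 (0.12 log units; within the scatter). For compound 4 in this assay the estimated value is 210 nM, with an expected range from 100 nM to 450 nM.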

Compound 4, concentration lethal to 50% of the cells: 110 nM
Compound 4: middle estimate off by 1.9-fold (0.28 log units), on the high side; the range from low to high includes it.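

In this assay, going from isopropyl to ethyl on the core of compound 2 gives a 1.5-fold lower number from compound 2 to compound 4 (0.16 log units; within the scatter), so on this core the change stays inside the usual scatter. Set beside the step on the core of compound 1, the two show no difference that can be told apart: the same change on two cores in this assay, a 1.3-fold higher number (0.10 log units; within the scatter) from compound 3 to compound 1 and a 1.5-fold lower number (0.16 log units; within the scatter) from compound 2 to compound 4, 1.8-fold (0.26 log units) apart, within the scatter of two such steps. Among these compounds, this supports carrying hydrogen in place of methyl from one core to the other as a small step in this assay, but it does not show that the two cores respond identically, as each core supplies only one pair of compounds and any true difference smaller than the scatter would stay hidden.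

The compounds shown leave open whether a step beyond the scatter appears on either core when the alkyl group gives way to a longer chain, a lone methyl or a cyclopropyl ring. Also open, on these data alone, is what an amine or a carboxylic acid on that chain would do, and whether the same reading holds on cells other than those of this assay.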